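Sulfamoyl amine swap: dimethyl to diethyl

The source may hold more compounds than are shown below. What is called first, only, known or untested is meant among the compounds shown, and "the series" means these compounds.

The series shares one core: compound 1 `O=C([C@@H]1CCCN(S(=O)(=O)c2ccc(S(=O)(=O)N3CC[C@@H](O)C3)cc2)C1)N1CCC(F)(F)CC1`, compound 2 `CCN(CC)S(=O)(=O)c1ccc(S(=O)(=O)N2CCC[C@@H](C(=O)N3CCC(C(F)(F)F)CC3)C2)cc1` and compound 3 `CN(C)S(=O)(=O)c1ccc(S(=O)(=O)N2CCC[C@@H](C(=O)N3CCC(F)(F)CC3)C2)cc1` differ only at the amine on the sulfonyl sulfur and at the amide end. In a functional assay on MIA PaCa-2 cells (Homo sapiens) for inhibition, read by MTT assay, with a stated time of 3 days (a higher number here means a weaker inhibitor, a lower number a stronger inhibitor), compound 1 gives 135 nM, compound 2 gives 110 nM and compound 3 gives 72.4 nM, the lowest of the three numbers, though its gaps to both other compounds lie within the usual scatter. For the measured compounds named here, the only single-point step measured so far, a 1.9-fold lower number from compound 1 to compound 3 (0.27 log units; within the scatter), also stays within the scatter.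

Compound 4 `CCN(CC)S(=O)(=O)c1ccc(S(=O)(=O)N2CCC[C@@H](C(=O)N3CCC(F)(F)CC3)C2)cc1` is compound 3 with diethylamino in place of dimethylamino on a sulfonyl sulfur. Going by the values given here, no measured step covers this exact change. Compound 2 carries the diethylamino group on the sulfonyl sulfur, and its number and that of compound 3 lie within the scatter of each other, but the two compounds also differ at the amide end, so that comparison is only suggestive. Among the compounds with values here, the one step at this position, from the 3-hydroxypyrrolidin-1-yl group to the dimethylamino group, moved the number only within the scatter. The expected step, a 1.2-fold higher number from compound 3 to compound 4 (0.07 log units; within the scatter), is therefore estimated to stay within the scatter as well. Compound 4 is expected to give about 85 nM in this assay, with a likely range of 45 nM to 165 nM.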

Compound 4, half-maximal inhibitory concentration: 19 nM
Beside the measured number, compound 4's estimate is 4.5-fold (0.65 log units) above it; measured number below the stated range.
By their numbers in this assay, from the lowest: compound 4; then compounds 3, 2 and 1 (each within the scatter of the next).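

In this assay the amine on the sulfonyl sulfur now shows a clear effect: with the 4,4-difluoropiperidin-1-yl amide held fixed, diethylamino gives a 3.8-fold lower number from compound 3 to compound 4 (0.58 log units; beyond the scatter) and, against 3-hydroxypyrrolidin-1-yl, a 7.1-fold lower number from compound 1 to compound 4 (0.85 log units; beyond the scatter), whereas the earlier step from 3-hydroxypyrrolidin-1-yl to dimethylamino stayed within the scatter. The amide end responds as well: with diethylamino held fixed, 4,4-difluoropiperidin-1-yl in place of 4-(trifluoromethyl)piperidin-1-yl gives a 5.8-fold lower number from compound 2 to compound 4 (0.76 log units; beyond the scatter). Nothing available here explains either change.

Open, on these data alone, is whether the number keeps falling with a longer chain on the sulfonamide nitrogen, such as dipropylamino, or with a branched amine such as diisopropylamino. Also open, as far as these compounds go, is whether the amide-end step carries over when dimethylamino sits on the sulfonyl sulfur.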